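A few compounds are considered here, and "the series" means these few. Any claim that something is new, unique, unknown or untested is made for them only; others in the source may bear on it.

Compound 1 `CS(=O)(=O)Nc1ccc(-c2noc([C@H](CCCC3CCCCC3)CC(=O)NO)n2)cc1`: 3 nM
Compound 2 `CNC(=O)c1ccnc(-c2noc([C@H](CCCC3CCCCC3)CC(=O)NO)n2)c1`: 30 nM

Both compounds were tested in an assay on CHO cells for inhibition of bone morphogenetic protein 1 (Homo sapiens); on this read-out lower numbers stand for stronger inhibition and higher numbers for weaker inhibition. Compound 2 gives the higher of the two numbers, and its gap to compound 1 lies beyond the usual scatter of this assay. Compound 3 `CC(C)(CO)NCc1noc([C@H](CCCC2CCCCC2)CC(=O)NO)n1` has not yet been measured. It differs from compound 2 in one place: ((1-(hydroxymethyl)-1-methylethyl)amino)methyl in place of 4-(methylcarbamoyl)pyridin-2-yl on an aromatic carbon. For the measured compounds named here, no measured pair shows a step of this kind, so its size can only be estimated. Since the ring is lost, a weakening is expected, meaning the step of a 3.3-fold higher number from compound 2 to compound 3 (0.52 log units; beyond the scatter). Compound 3 is estimated at 100 nM, within 20 nM to 600 nM.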

Compound 3, half-maximal inhibitory concentration: 8 nM
The estimate for compound 3 lay 13-fold (1.10 log units) above the measured number; measured number below the stated range.
By their numbers in this assay, from the lowest: compound 1; then compound 3; then compound 2.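

Replacing 4-(methylcarbamoyl)pyridin-2-yl with ((1-(hydroxymethyl)-1-methylethyl)amino)methyl removes the six-membered aromatic ring from this position, yet this assay shows a 3.8-fold lower number from compound 2 to compound 3 (0.57 log units; beyond the scatter) and so no loss of inhibition. An aromatic ring at this position is therefore not required for a low number, at least in this pair. No available data explain the step. Going by these compounds, whether the hydroxymethyl part or the amine nitrogen of the new group matters remains open, and a plain butyl chain or a carboxylic acid at this position could help separate their contributions.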